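The compounds below may be only part of what the source reports. "The series", "measured", "known", "first", "only" and "open" are said of these compounds alone.

Working notes on the series. Compound 1 `O=S(=O)(NCCCNCC1COc2ccccc2O1)c1cc(C(F)(F)F)cc(C(F)(F)F)c1` gives 1200 nM in a functional assay on BXPC-3 cells (Homo sapiens) for inhibition, read by MTT assay, with a stated time of 72 h (on this read-out lower numbers stand for stronger inhibition of growth and higher numbers for weaker inhibition of growth), and compound 2 `O=S(=O)(NCCCNCc1ccc(-c2ccccc2)cc1)c1cc(C(F)(F)F)cc(C(F)(F)F)c1` gives 1700 nM in this assay. Compound 3 `CN(CCCNS(=O)(=O)c1cc(C(F)(F)F)cc(C(F)(F)F)c1)Cc1ccccc1` stands highest of the three numbers, with 39000 nM in this assay; its nearest neighbour, compound 2, lies beyond the scatter, as does compound 1.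

Compound 4 `O=S(=O)(NCCCNCc1ccccc1)c1cc(C(F)(F)F)cc(C(F)(F)F)c1` differs from compound 3 by hydrogen in place of methyl on an amine nitrogen, which returns the amine to the secondary form seen in compound 1 and compound 2. Among the measured compounds shown here, no directly comparable step is available among the measured compounds. The number for compound 4 is expected to fall, with a step of a 6.5-fold lower number from compound 3 to compound 4 (0.81 log units; beyond the scatter), because compound 1 at 1200 nM and compound 2 at 1700 nM both carry a secondary amine and sit far lower than compound 3. Compound 4 is estimated at 6000 nM, within a range from 1500 nM to 25000 nM.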

Compound 4, concentration for 50% growth inhibition: 13000 nM
Compound 4: middle estimate off by 2.2-fold (0.34 log units), on the low side, within the range that was stated.
By their numbers in this assay, from the lowest: compounds 1 and 2 (each within the scatter of the next); then compound 4; then compound 3.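

In this assay, removing the methyl from the amine nitrogen gives only a partial fall, with a 3.0-fold lower number from compound 3 to compound 4 (0.48 log units; beyond the scatter), and the secondary amine alone does not bring the number down to the level of compound 1 or compound 2. The rest of the amine substituent also counts: hydrogen in place of phenyl on an aromatic carbon gives a 7.6-fold higher number from compound 2 to compound 4 (0.88 log units; beyond the scatter), while phenyl in place of 2,3-dihydro-1,4-benzodioxin-2-yl gives an 11-fold higher number from compound 1 to compound 4 (1.03 log units; beyond the scatter). No evidence on hand accounts for these steps.

Open, as far as these compounds go, is whether methyl on the amine nitrogen of compound 1 or compound 2 would raise the number by a similar step. Also open, from the compounds shown here alone, is how an ethyl group on that nitrogen would read.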